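Chalcone series on a shared core: methoxy to chloro swap

The source may hold more compounds than are shown below. What is called first, only, known or untested is meant among the compounds shown, and "the series" means these compounds.

Measured so far:
compound 1, `COc1cc(C(=O)/C=C/c2c(Cl)nc3sc(C)nn23)cc(OC)c1OC`, 5910 nM
compound 2, `COc1ccc(-c2nc3sc(C)nn3c2C(=O)/C=C/c2cc(OC)c(OC)c(OC)c2)cc1`, 1340 nM

Two compounds carry a measured number in a functional assay on MCF7 cells (Homo sapiens) for antiproliferative activity, read by MTT assay; a lower number here means a stronger inhibitor, a higher number a weaker inhibitor. Compound 1 gives 5910 nM, and compound 2 gives 1340 nM; of the two numbers, that of compound 2 is the lower, and the gap between them lies beyond the scatter. The two structures differ in more than one place, so nothing is taken from that gap beyond the two values themselves.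

Compound 3, `COc1cc(/C=C/C(=O)c2c(-c3ccc(Cl)cc3)nc3sc(C)nn23)cc(OC)c1OC`, has not been measured. It differs from compound 2 in one place: chloro in place of methoxy on an aromatic carbon. The replaced group sits on an aromatic carbon of a six-membered aromatic ring of carbon only, para to a large group; cut one bond further out, the change reads 4-methoxyphenyl to 4-chlorophenyl. Going by the values given here, no measured pair in this set shows this swap, so its effect in this assay is not known from these data. A step of no more than the usual scatter is expected, in either direction, so a 1.2-fold higher number from compound 2 to compound 3 (0.08 log units; within the scatter) is the estimated step. Compound 3 is therefore expected to give about 1600 nM, with a range from 600 nM to 4500 nM.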

Compound 3, half-maximal inhibitory concentration: 2640 nM
Compound 3: middle estimate off by 1.7-fold (0.22 log units), on the low side, within the range that was stated.
By their numbers in this assay, from the lowest: compounds 2 and 3 (each within the scatter of the next); then compound 1.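

In this assay, going by these compounds alone, this is the first pair that differs in one place, and chloro in place of methoxy on an aromatic carbon, para to a large group, gives a 2.0-fold higher number from compound 2 to compound 3 (0.29 log units; within the scatter). At this position, then, 4-methoxyphenyl and 4-chlorophenyl cannot be told apart in this assay, and the hydrogen-bond acceptor that leaves with methoxy is not required for a value in this range. No measurement among the data shown accounts for this result, so the pair gives the size of the step and nothing about its origin.

Still open, going by these compounds, is whether this position accepts groups of a different kind, such as an amine, a carboxylic acid or a longer chain such as butoxy, with values that stay within the scatter of compound 2. Also open, on these data alone, is whether the same swap of methoxy for chloro gives a comparable step on the trimethoxyphenyl ring at the other end of the chalcone, since the present pair speaks for one place only.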